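The compounds below may be only part of what the source reports. "The series", "measured", "known", "first", "only" and "open" are said of these compounds alone.

Compound 1 `Nc1ccccc1NC(=O)c1ccc(CSC(=S)N2CCN(c3ccccc3)CC2)cc1` gives 27.5% in a functional assay on A-375 cells (Homo sapiens) for antiproliferative activity, read by CCK-8 assay, with a stated time of 72 h, tested at 2 uM; a lower number here means a weaker effect, a higher number a stronger effect of the compound at the concentration tested.
Compound 2 `Cc1ccc(N2CCN(C(=S)SCc3ccc(C(=O)Nc4ccccc4N)cc3)CC2)cc1` gives 25.8% in this assay.

Compound 2 stands lowest of the two numbers, with compound 1 nearest, and that difference lies within the scatter. Compound 3 `Nc1ccccc1NC(=O)c1ccc(CSC(=S)N2CCN(c3ncccn3)CC2)cc1` differs from compound 2 by pyrimidin-2-yl in place of 4-methylphenyl on an amine nitrogen in a ring. Among the measured compounds shown here, the only measured step, a number 1.7 percentage points lower from compound 1 to compound 2 (within the scatter), altered a different part of the molecule and stayed within the scatter; no measured step exchanges the ring on the amine nitrogen. The change to compound 3 is therefore expected to give a step of a number 0.8 percentage points lower from compound 2 to compound 3 (within the scatter) in this assay, not beyond the scatter. Compound 3 is expected to give 25%, within a range from 12% to 40%.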

Compound 3, a percentage reported as inhibition, at one concentration (the size of the read-out at that concentration, not a potency): 24%
Compound 3: middle estimate off by 1 percentage points, on the high side, within the range that was stated.
By their numbers in this assay, from the lowest: compounds 3, 2 and 1 (each within the scatter of the next).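

Among the compounds shown here, this is the first measured exchange of the ring on the amine nitrogen in a ring. Pyrimidin-2-yl in place of 4-methylphenyl gives a number 1.8 percentage points lower from compound 2 to compound 3 (within the scatter) and pyrimidin-2-yl in place of phenyl gives a number 3.5 percentage points lower from compound 1 to compound 3 (within the scatter) in this assay so at this one concentration, an aromatic ring with 2 hetero atoms and a ring of carbon only cannot be told apart. No evidence is available to explain this result. Still open, from the compounds shown here alone, is whether a non-aromatic group on this nitrogen, such as cyclohexyl or acetyl, would read differently.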